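A few compounds are considered here, and "the series" means these few. Any claim that something is new, unique, unknown or untested is made for them only; others in the source may bear on it.

In a functional assay on K562 cells (Homo sapiens) for antiproliferative activity, read by MTT assay, with a stated time of 72 h (a higher number here means a weaker inhibitor, a lower number a stronger inhibitor), compound 1 `COc1cc(C(=O)c2sc3ccccc3c2-c2ccc(C)cc2)cc(OC)c1OC` gives 3500 nM. Compound 2 `COc1ccc(OC)c(-c2c(C(=O)c3cc(OC)c(OC)c(OC)c3)sc3ccccc23)c1` gives > 10000 nM, which is a limit of the assay and not a number. From the compounds shown here alone, compound 2 therefore stands at the limit of > 10000 nM in this assay, at which 1 of the 2 values shown sits, and its true position remains unknown.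

The next compound, compound 3 `CCOc1ccc(-c2c(C(=O)c3cc(OC)c(OC)c(OC)c3)sc3ccccc23)cc1`, changes the same aromatic carbon of the shared core: 4-ethoxyphenyl in place of 2,5-dimethoxyphenyl on an aromatic carbon. In words, this puts 4-ethoxyphenyl in place of 2,5-dimethoxyphenyl on an aromatic carbon, next to the ring atom that bears a large group.

Within the data shown here, only one measured step bears on this change. It is an at least 2.8-fold higher number from compound 1 to compound 2 (0.45 log units; beyond the scatter), which came with 2,5-dimethoxyphenyl in place of 4-methylphenyl and lies beyond the scatter. Compound 3 gives up the 2,5-dimethoxyphenyl group and, like compound 1, carries a single group named at the 4-position of its phenyl, so a move back towards 3500 nM of compound 1 seems likely in this assay. That makes a modest step to a lower number the expectation, although a second limit reading remains possible. The expected step is an at least 2.2-fold lower number from compound 2 to compound 3 (0.34 log units; beyond the scatter). For compound 3 the estimated value is 4500 nM, with an expected range from 1200 nM to 10000 nM.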

Compound 3, half-maximal inhibitory concentration: 3100 nM
Compound 3: middle estimate off by 1.5-fold (0.16 log units), on the high side, and the stated range covers the measured number.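

In this assay, the aromatic carbon two ring bonds from the ring sulfur now shows that an oxygen-bearing phenyl group can stand there without reaching the limit: an at least 3.2-fold lower number from compound 2 to compound 3 (0.50 log units; beyond the scatter). The high reading of compound 2 therefore does not extend to 4-ethoxyphenyl, and the 2,5-dimethoxyphenyl group remains the only one shown at that limit. The new comparison with compound 1 reads a 1.1-fold lower number from compound 1 to compound 3 (0.05 log units; within the scatter), so with ethoxy in place of methyl on the phenyl ring, compound 1 and compound 3 cannot be told apart in this assay.

Compound 2 gives > 10000 nM, which is a limit of the assay and not a number: the limit of > 10000 nM in this assay, at which 1 of the 3 values shown sits.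

The compounds shown leave open whether a single methoxy group on the phenyl ring, rather than the pair in 2,5-dimethoxyphenyl, would also give a reading at the limit. They also leave open how a longer chain such as butoxy, an amine or a carboxylic acid in place of the ethoxy of compound 3 would read in this assay.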